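The compounds below may be only part of what the source reports. "The series", "measured", "known", "first", "only" and "open" are said of these compounds alone.

Measured compounds:
compound 1 `N#Cc1cccc(-c2cccc(C(F)(F)F)c2)n1` — 2880 nM
compound 2 `N#Cc1cc(-c2ccc(OCCCO)c(C(F)(F)F)c2)ccn1` — "not active" (no number reported)

In an assay on isolated protein for inhibition of cathepsin S (Homo sapiens), read by fluorescence (a lower number here means a stronger inhibitor, a higher number a weaker inhibitor), compound 1 gives 2880 nM, a weak result. Compound 2 has no number: in this assay compound 2 is reported as "not active" (no number reported), so it stands below any measurable activity on the numbers shown, and nothing more can be read from it than that. Going by the values given here, compound 1 and compound 2 differ in several places at once, so no single step between them can be set out.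

Compound 3 `N#Cc1cc(-c2ccc(OCCN3CCCC3=O)c(C(F)(F)F)c2)ccn1` is the next member. Relative to compound 2 the change is 2-oxopyrrolidin-1-yl in place of hydroxymethyl on a saturated chain carbon, two bonds along the chain from an oxygen on an aromatic ring. Among the compounds with values here, no measured pair covers this change, so its size cannot be taken from the data. Given that compound 2 shows no activity and the change leaves the rest of the molecule untouched, any shift is expected to be modest and may not lift compound 3 out of the inactive range. Compound 3 is estimated at 15000 nM in this assay, expected range 3000 nM to 60000 nM, with a substantial chance that only a limit is reported.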

Compound 3, half-maximal inhibitory concentration: "not active" (no number reported)
Compound 3 has no reported number here, so the estimate cannot be set against anything.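

Compound 2 and compound 3 are both reported as not active in this assay, so no step can be read between them. No evidence bears on this result. The compounds shown leave open how far 3-hydroxypropoxy and 2-(2-oxopyrrolidin-1-yl)ethoxy differ in their effect on inhibition.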